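Chloro for Fluoro on a Fused Ring: Cytotoxicity Outlook

The source may report more compounds than this note shows. Statements on the series, on what has been measured and on what is new or still open speak of the compounds shown alone.

Compound 1 `O=C(Nc1nc(-c2cccc(F)c2)cs1)c1cc([N+](=O)[O-])ccc1Cl` gives 8700 nM in an ADME assay on HEK293 cells (Homo sapiens) for cytotoxicity, with a stated time of 72 h; on this read-out higher numbers stand for an effect only at larger amounts of compound and lower numbers for an effect already at smaller amounts.
Compound 2 `COc1ccc(-c2nc3ccccc3s2)cc1NC(=O)c1cc([N+](=O)[O-])ccc1Cl` gives > 25000 nM in this assay, which is a limit of the assay and not a number.
Compound 3 `O=C(Nc1nc2ccc(F)cc2s1)c1cc([N+](=O)[O-])ccc1Cl` gives > 27000 nM in this assay, which is also a limit of the assay and not a number.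

Compound 3 therefore has no exact value in this assay, only a limit; it sits at the limit of > 27000 nM in this assay, at which 1 of the 3 values shown sits. Among the three values shown, one further value is likewise a limit, namely (the limit of > 25000 nM in this assay, at which 1 of the 3 values shown sits). Only compound 1 gives an actual number, and it lies lower than both limits.

Compound 4 `O=C(Nc1nc2ccc(Cl)cc2s1)c1cc([N+](=O)[O-])ccc1Cl` differs from compound 3 by a single change: chloro in place of fluoro on an aromatic carbon. Among the compounds with values here, no pair of compounds that differ in one place has been measured here, so there is no measured step to lean on. Since compound 3 reports only a limit, the change to compound 4 is expected to give no step beyond the usual scatter in this assay, and most likely compound 4 will again return a limit rather than a number.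

Compound 4 is expected to come out near 30000 nM, in a range from 12000 nM to 80000 nM. The estimated step that the limit leaves unreadable from compound 3 to compound 4 is thus expected to stay within the scatter.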

Compound 4, half-maximal effective concentration: > 27000 nM
Compound 4: only a limit was reported (the forecaster's own chance of this, stated with the estimate: 70%); the middle value does not contradict the limit.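

Compound 3 and compound 4 both return only a limit of the assay and not a number, so no step between them can be read in this assay: the limit of > 27000 nM in this assay, at which 2 of the 4 values shown sit.

The compounds shown leave open what actual number either compound would give, and so whether chloro in place of fluoro on an aromatic carbon shifts this read-out at all.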